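This account rests on a few compounds, and the source may have more. Where it says the series, first, only, none or still open, it means among the compounds named here.

Measured so far in this series:
compound 1 `CC(C)c1onc(-c2c(Cl)cccc2Cl)c1COc1ccc(NC(=O)c2ccc(C(=O)O)cc2)c(C(F)(F)F)n1`: 21%
compound 2 `Cc1nc(OCc2c(-c3c(Cl)cccc3Cl)noc2C(C)C)ccc1N(C)C(=O)c1ccc(C(=O)O)cc1`: 21%
compound 3 `CC(C)c1onc(-c2c(Cl)cccc2Cl)c1COc1ccc(N(C)C(=O)c2cccc(C(=O)O)c2)c(C(F)(F)F)n1`: 35%

In a functional assay on HEK293 cells for agonist activity at Bile acid receptor (Homo sapiens) (on this read-out lower numbers stand for smaller maximal responses and higher numbers for larger maximal responses), compound 3 gives 35%, the highest of the three numbers. Compound 1 gives 21% and compound 2 gives 21%; each lies below compound 3 by a gap beyond the scatter, while the two of them agree with each other within it. Going by the values given here, no two of the measured compounds differ in a single place, so no single step has yet been measured in this assay.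

Compound 4 `CC(C)c1onc(-c2c(Cl)cccc2Cl)c1COc1ccc(N(C)Cc2cccc(C(=O)O)c2)c(C(F)(F)F)n1` is not yet measured. It differs from compound 3 in one place: 3-carboxybenzyl in place of (3-carboxyphenyl)carbonyl on a nitrogen on an aromatic ring The (3-carboxyphenyl)carbonyl leaves and 3-carboxybenzyl enters on a nitrogen on an aromatic ring whose other neighbours are an aromatic carbon and a saturated chain carbon.

Among the compounds with values here, no measured step of this kind exists among the three compounds, so its size is open. The expected step is a number 13 percentage points lower from compound 3 to compound 4 (beyond the scatter), a decrease beyond the scatter. Compound 4 is estimated at 22% in this assay, within a range from 5% to 50%.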

Compound 4, largest response reached (reported as efficacy), in percent of the reference or control that the assay uses: 89%
For compound 4 the middle estimate is 67 percentage points below the measured one, outside the stated range (above it).
By their numbers in this assay, from the lowest: compounds 1 and 2 (each within the scatter of the next); then compound 3; then compound 4.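

In this assay, the first step measured at this position is large: 3-carboxybenzyl in place of (3-carboxyphenyl)carbonyl on the nitrogen on an aromatic ring gives a number 54 percentage points higher from compound 3 to compound 4 (beyond the scatter). The maximal response at this receptor therefore depends strongly on what links that nitrogen to the carboxyphenyl ring, since the entering group keeps the aromatic ring and the carboxylic acid and has one double bond fewer outside aromatic rings. The wider exchange of ((4-carboxyphenyl)carbonyl)amino for (3-carboxybenzyl)(methyl)amino on an aromatic carbon gives a number 68 percentage points higher from compound 1 to compound 4 (beyond the scatter), but it changes several features at once and cannot assign the gain to any one of them.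

Still open, going by these compounds, is how the response changes with a longer chain on that nitrogen, or with a tetrazole in place of the carboxylic acid. Nothing available here explains the size of the step.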